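A Semicarbazide Replaces the Aryl Urea

A few compounds are considered here, and "the series" means these few. Any claim that something is new, unique, unknown or untested is made for them only; others in the source may bear on it.

Compound 1: `COc1cc(NC(C)CCCNC(=O)NNC(=O)N(CCO)CCO)c2ncccc2c1` gives > 100000 nM in a functional assay on SW-620 cells (Homo sapiens) for inhibition, read by MTT assay, with a stated time of 4 days (on this read-out higher numbers stand for weaker inhibition and lower numbers for stronger inhibition), a limit of the assay.
Compound 2: `COc1cc(NC(C)CCCNC(=O)Nc2ccc(Cl)c(C(F)(F)F)c2)c2ncccc2c1` gives 23000 nM in this assay.
Compound 3: `COc1cc(NC(C)CCCNC(=O)NNC(=O)NCCCC(C)Nc2cc(OC)cc3cccnc23)c2ncccc2c1` gives > 100000 nM in this assay, a limit of the assay.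

Among the three measured compounds, compound 2 is the only one with a number in this assay; the other two values are limits. For the measured compounds named here, the single measured step, an at least 4.3-fold lower number from compound 1 to compound 2 (0.63 log units; beyond the scatter), shows that putting the 4-chloro-3-(trifluoromethyl)phenyl group on the amide-type nitrogen moves the value away from the limit, as the limit of > 100000 nM in this assay, at which 2 of the 3 values shown sit, records.

Compound 4, `COc1cc(NC(C)CCCNC(=O)NN)c2ncccc2c1`, has not yet been measured. It differs from compound 2 in one place: amino in place of 4-chloro-3-(trifluoromethyl)phenyl on an amide-type nitrogen. This reverses the kind of change seen in the measured step, taking away the aryl group and leaving a small nitrogen substituent, as compound 1 and compound 3 also carry in this position.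

Because of an at least 4.3-fold lower number from compound 1 to compound 2 (0.63 log units; beyond the scatter), the change from compound 2 to compound 4 is expected to raise the value, with an estimated step of a 4.3-fold higher number from compound 2 to compound 4 (0.64 log units; beyond the scatter). For compound 4 the estimated value in this assay is 100000 nM, with a range from 30000 nM to 300000 nM, and it is expected that the assay may again report only a limit.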

Compound 4, half-maximal inhibitory concentration: > 100000 nM
Compound 4 gave a limit, no number (the forecaster's own chance of this, stated with the estimate: 65%); the middle value sits exactly at the limit.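

Taken together with the earlier step, the new one tests the same position from the other direction. For the compounds shown here, with amino in place of 4-chloro-3-(trifluoromethyl)phenyl on the amide-type nitrogen, this assay gives an at least 4.3-fold higher number from compound 2 to compound 4 (0.63 log units; beyond the scatter), so the only number in the set is lost in a single change that adds no carbonyl-bearing substituent, unlike the groups in compound 1 and compound 3. The value of compound 4 is a limit and not a number, and it stands with compound 1 and compound 3 at the same ceiling: the limit of > 100000 nM in this assay, at which 3 of the 4 values shown sit.

The step from compound 1 to compound 4 cannot be read, as both values are limits, so the bare amino group and the (bis(2-hydroxyethyl)carbamoyl)amino group cannot be ranked against each other. The compounds shown leave open which part of the 4-chloro-3-(trifluoromethyl)phenyl group goes with the measurable value, and whether a plain phenyl, a 4-chlorophenyl, a 3-(trifluoromethyl)phenyl or a cyclohexyl ring on the same nitrogen would keep it.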